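Methoxy for ethyl on the fused aromatic ring

The compounds below may be only part of what the source reports. "The series", "measured", "known", "first", "only" and "open" are said of these compounds alone.

Working notes on the series. Compound 1 `Cc1cccc2nc(N3CCN(C)CC3)oc12` and compound 2 `CCc1cc(C)cc2nc(N3CCN(C)CC3)oc12` share the same core and have both been measured in an assay on ileum (strain Hartley) with 5-hydroxytryptamine receptor 3A (Cavia porcellus) as the target; a higher number here means a larger maximal response, a lower number a smaller maximal response. Compound 1 gives 0.58 there. Compound 2 gives 0.26 in this assay, the lower of the two numbers in hand, and the gap to compound 1 lies beyond the scatter of repeated measurements. The two compounds differ in more than one place, so no single step can be read between them.

Compound 3 `COc1cc(C)cc2nc(N3CCN(C)CC3)oc12` is not yet measured. Relative to compound 2 the change is methoxy in place of ethyl on an aromatic carbon, sitting on an aromatic carbon of the six-membered ring of carbon only, ortho to a fused ring and meta to a methyl group. Within the data shown here, no measured step of this kind exists, so the direction is open. The expectation is a step from compound 2 to compound 3 of a number 0.070 higher from compound 2 to compound 3 (within the scatter) in this assay, small and not clearly beyond the scatter. The estimate for compound 3 in this assay is 0.33, with a range from 0.15 to 0.58.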

Compound 3, intrinsic activity: the largest response reached, as a fraction of the reference agonist's: 0.56
Compound 3: middle estimate off by 0.23, on the low side; the range from low to high includes it.
By their numbers in this assay, from the lowest: compound 2; then compounds 3 and 1 (each within the scatter of the next).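

The series now has a step that can be read in one place: in this assay the maximal response lies a number 0.30 higher from compound 2 to compound 3 (beyond the scatter) with methoxy in place of ethyl on an aromatic carbon, ortho to a fused ring and meta to a methyl group. The earlier compounds shown here could not show this, as compound 1 and compound 2 differ in more than one place. At this position the read-out therefore separates two groups of 2 heavy atoms each, where methoxy holds one oxygen and 1 hydrogen-bond acceptor and ethyl holds neither, and nothing at hand explains the step.

Only ethyl and methoxy are shown at this position, so it stays open how a hydroxyl, an amine or a longer chain such as propoxy would read there. As far as these compounds go, it also stays open whether the step would hold on a core without the methyl group, as compound 1 differs from compound 2 and from compound 3 in more than one place.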